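This account rests on a few compounds, and the source may have more. Where it says the series, first, only, none or still open, it means among the compounds named here.

Measured so far in an ADME assay on LLC-MK2 cells (Macaca mulatta) for cytotoxicity, read by spectrophotometry and crystal violet staining, with a stated time of 4 days; a higher number here means that more compound is tolerated, a lower number that less compound is tolerated:

- compound 1 `CC(C)n1ncc2c(C(=O)Nc3ccc(F)cc3)cc(-c3ccco3)nc21`: > 200000 nM
- compound 2 `CC(C)n1ncc2c(C(=O)Nc3ccc(F)cc3)cc(-c3cccs3)nc21`: > 200000 nM
- compound 3 `CC(C)n1ncc2c(C(=O)Nc3ccc(F)cc3)cc(C3CC3)nc21`: 12500 nM

Compound 2 stands at a limit in this assay, not at a number. Compound 1 likewise reports only a limit, so that two of the three values sit at the same ceiling (the limit of > 200000 nM in this assay, at which 2 of the 3 values shown sit). Between these two the step that the two limits leave unreadable from compound 1 to compound 2 cannot be read. Compound 3 alone gives a number, and the steps of an at least 16-fold lower number from compound 1 to compound 3 (1.20 log units; beyond the scatter) and an at least 16-fold lower number from compound 2 to compound 3 (1.20 log units; beyond the scatter) are both large; each concerns the group on the aromatic carbon of the shared core.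

Compound 4 `CC(C)n1ncc2c(C(=O)Nc3ncccn3)cc(-c3cccs3)nc21` differs from compound 2 elsewhere: pyrimidin-2-yl in place of 4-fluorophenyl on an amide-type nitrogen. Within the data shown here, none of the measured steps touches the amide-type nitrogen, so no measured step bears directly on this change, and nothing in the data points to a shift beyond the scatter. The expected step is therefore a number no higher from compound 2 to compound 4 (the limit leaves the size open), and compound 4 is expected to give about 200000 nM, in the range 50000 nM to 400000 nM, most probably again reported only as a limit.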

Compound 4, half-maximal cytotoxic concentration: 75000 nM
Estimate against measurement, compound 4: 2.7-fold (0.43 log units) above, within the range that was stated.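

The amide-type nitrogen now has a measured step of its own in this assay: with thiophen-2-yl held on the aromatic carbon, the change gives an at least 2.6-fold lower number from compound 2 to compound 4 (0.42 log units; beyond the scatter) and is beyond the scatter. Among these compounds, the earlier steps concerned only the group on the aromatic carbon, so this is the first sign that the group on the amide-type nitrogen also moves the read-out, though less clearly than cyclopropyl did on the aromatic carbon. The step has only a lower bound, since compound 2 stands at a limit and its true value is unread: the limit of > 200000 nM in this assay, at which 2 of the 4 values shown sit.

As far as these compounds go, whether pyrimidin-2-yl has a similar effect with furan-2-yl or cyclopropyl on the aromatic carbon remains open. Also open, from the compounds shown here alone, is how an unsubstituted phenyl or a pyridin-2-yl on the amide-type nitrogen would read, and so whether the ring nitrogens of pyrimidin-2-yl or the loss of the fluorine goes with the drop.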